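The compounds below may be only part of what the source reports. "The series", "measured", "known", "first", "only" and "open" are said of these compounds alone.

Measured in a functional assay on HT-29 cells (Homo sapiens) for antiproliferative activity, read by sulforhodamine B assay, with a stated time of 48 h; on this read-out lower numbers stand for stronger inhibition and higher numbers for weaker inhibition:

- Compound 1 `CCCCc1ccc(NS(=O)(=O)c2ccc(N3CCNC3=O)cc2)cc1`: 610 nM
- Compound 2 `O=C1NCCN1c1ccc(S(=O)(=O)Nc2ccc(F)c(F)c2)cc1`: 350 nM

Among the measured compounds shown here, only two compounds have a number so far. Compound 1 gives 610 nM and compound 2 gives 350 nM. These two values lie within the usual scatter of repeated measurements, so they cannot be ranked, and compound 1 stands level with compound 2.

The next compound to be tested is compound 3 `O=C1NCCN1c1ccc(S(=O)(=O)Nc2ccc(OC(F)F)cc2)cc1`. It is made from compound 1 by one change: difluoromethoxy in place of butyl on an aromatic carbon, para to a large group (difluoromethoxy in place of butyl on an aromatic carbon).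

For the measured compounds named here, no two measured compounds differ in one place only, so no measured step shows what a single swap does here. Going by the values given here, the only guide is that the two known values sit close together. In this assay, the expectation is therefore a step no larger than the scatter, with no firm direction.

For compound 3 the estimated value is 500 nM, with an expected range from 170 nM to 1500 nM. This estimate amounts to an expected 1.2-fold lower number from compound 1 to compound 3 (0.09 log units; within the scatter).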

Compound 3, half-maximal inhibitory concentration: 650 nM
Compound 3: middle estimate off by 1.3-fold (0.11 log units), on the low side; measured number inside the range.
By their numbers in this assay, from the lowest: compounds 2, 1 and 3 (each within the scatter of the next).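

Among the compounds shown here, this is the first step that changes only one place. In this assay, putting difluoromethoxy in place of butyl on an aromatic carbon, para to a large group, gives a 1.1-fold higher number from compound 1 to compound 3 (0.03 log units; within the scatter). Both groups hold 4 heavy atoms, but butyl is all carbon with no hydrogen-bond acceptor, while difluoromethoxy holds carbon, oxygen and fluorine and counts 1 hydrogen-bond acceptor, so this difference in make-up comes with no step beyond the scatter for this pair. No measurement on hand offers an explanation for this result, so it stands as an observation about these two compounds only.

One swap cannot show whether this position matters in general, since a different group there, such as an amine, a carboxylic acid or a longer chain, might or might not move the number beyond the scatter. As far as these compounds go, compound 2 differs from the other two compounds in more than one place, so what its difluoro pattern contributes on its own also remains open.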